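Oxane in place of acetylpiperidine on the shared core

This account rests on a few compounds, and the source may have more. Where it says the series, first, only, none or still open, it means among the compounds named here.

Compound 3 `COc1cc(F)ccc1-c1ccnc2[nH]c(C3CCN(C(C)=O)CC3)cc12` stands at the low end of the numbers seen so far: in an ADME assay on microsomes from liver (Homo sapiens) for metabolic stability (on this read-out higher numbers stand for fast clearance and lower numbers for slow clearance), compound 3 is reported only as a limit, < 3 uL/min. Going by the values given here, compound 1 `COc1cc(F)ccc1-c1ccnc2[nH]c(C3CCN(CC(=O)N(C)C)CC3)cc12` gives 14 uL/min in this assay, and the step of an at least 4.6-fold lower number from compound 1 to compound 3 (0.66 log units; beyond the scatter) is the only measured step that touches compound 3; it ends at the limit of < 3 uL/min in this assay, at which 1 of the 3 values shown sits. Compound 4 `COc1cc(F)ccc1-c1ccnc2[nH]c(C3CCOCC3)cc12` differs from compound 3 by oxan-4-yl in place of 1-acetylpiperidin-4-yl on an aromatic carbon. Among the compounds with values here, no measured step covers this change; compound 2 `COc1cc(C(=O)N2CCCC2)ccc1-c1ccnc2[nH]c(C3CCOCC3)cc12`, which also carries oxan-4-yl but differs elsewhere, gives 74 uL/min in this assay. An increase is therefore expected for compound 4, an at least 6.0-fold higher number from compound 3 to compound 4 (0.77 log units; beyond the scatter), though its size is uncertain. The estimate for compound 4 in this assay is 18 uL/min, expected between 5 uL/min and 60 uL/min.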

Compound 4, intrinsic clearance in a liver preparation (reported as CLH), per the amount of preparation that the assay uses in the Homo sapiens assay: 10 uL/min
The estimate for compound 4 lay 1.8-fold (0.26 log units) above the measured number; the measured number falls inside the stated range.
By their numbers in the Homo sapiens assay, from the lowest: compounds 4 and 1 (each within the scatter of the next); then compound 2. At a limit, below all of these: compound 3.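

Going by these compounds alone, in the Homo sapiens assay, this position on the five-membered aromatic ring now has a direct comparison, which the earlier compounds lacked: oxan-4-yl in place of 1-acetylpiperidin-4-yl gives an at least 3.3-fold higher number from compound 3 to compound 4 (0.52 log units; beyond the scatter). With oxan-4-yl held constant, fluoro in place of (pyrrolidin-1-yl)carbonyl gives a 7.4-fold lower number from compound 2 to compound 4 (0.87 log units; beyond the scatter). In a physicochemical assay for solubility, in phosphate buffer, at pH 7.4 (on this read-out higher numbers stand for higher solubility and lower numbers for lower solubility), compound 3 gives 50000 nM and compound 4 gives 97000 nM, values within the scatter of each other.

From the compounds shown here alone, compound 3 is reported as a limit, so the full size of its step stays open: the limit of < 3 uL/min in the Homo sapiens assay, at which 1 of the 4 values shown sits. Going by these compounds, what a carboxylic acid or a longer chain on this aromatic carbon would give also stays open.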